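The source may report more compounds than this note shows. Statements on the series, on what has been measured and on what is new or still open speak of the compounds shown alone.

Measured compounds in a functional assay on BT-20 cells (Homo sapiens) for antiproliferative activity, read by trypan blue exclusion; a higher number here means a weaker inhibitor, a lower number a stronger inhibitor:

Compound 1 `COc1ccc(CS(=O)(=O)/C=C/c2ccc(OC)cc2OC)cc1` — in this assay compound 1 gives > 20000 nM, a limit of the assay and not a number.
Compound 2 `COc1ccc(CS(=O)(=O)/C=C/c2cc(OC)cc(OC)c2)cc1` — in this assay compound 2 gives > 20000 nM, also a limit and not a number.
Compound 3 `COc1ccc(CS(=O)(=O)/C=C/c2ccc(OC)c(OC)c2OC)cc1` — in this assay compound 3 gives > 20000 nM, again a limit and not a number.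

The step from compound 1 to compound 3 is methoxy in place of hydrogen on an aromatic carbon. Its size is a step that the two limits leave unreadable from compound 1 to compound 3; it is left unreadable by the limit of > 20000 nM in this assay, at which 3 of the 3 values shown sit. Compound 2 and compound 1 are built from the same atoms joined differently; the difference between the two cores is not broken down here.

The unmeasured compound 4 `COc1ccc(CS(=O)(=O)/C=C/c2cc(OC)c(OC)c(OC)c2)cc1` is made from compound 2 by methoxy in place of hydrogen on an aromatic carbon. Going by the values given here, this is the same kind of change as the one from compound 1 to compound 3, not the same change: in compound 2 the place is para to a large group, whereas in compound 1 it is meta to a large group.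

The step from compound 2 to compound 4 is estimated as a step that the limit leaves unreadable from compound 2 to compound 4, beside the unreadable earlier step. This rests on (the limit of > 20000 nM in this assay, at which 3 of the 3 values shown sit), at which compound 1, compound 2 and compound 3 all sit, and on the step from compound 1 to compound 3 having produced no readable change. For compound 4 the estimate in this assay is 30000 nM, with a range from 8000 nM to 100000 nM, and most likely the assay will again report only a limit.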

Compound 4, half-maximal inhibitory concentration: > 20000 nM
Compound 4 was reported as a limit (the forecaster's own chance of this, stated with the estimate: 80%); the middle value does not contradict the limit.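

In this assay compound 4 gives > 20000 nM, a limit of the assay and not a number. The step between compound 2 and compound 4 therefore cannot be read, and no new step emerges: the limit of > 20000 nM in this assay, at which 4 of the 4 values shown sit.

The compounds shown leave open whether any methoxy arrangement on the shared core gives a readable value in this assay, and how far compounds 1 to 4 lie beyond the limit.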